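Chloro for Bromo: Expecting Little Change in Growth Inhibition

This account rests on a few compounds, and the source may have more. Where it says the series, first, only, none or still open, it means among the compounds named here.

Three compounds have been measured in a functional assay on THP-1 cells (Homo sapiens) for inhibition, read by sulforhodamine B assay, tested at 10 uM; a lower number here means less inhibition of growth, a higher number more inhibition of growth at the concentration tested:
- compound 1 `COc1cc(C2CC(c3ccc(Br)cc3)=NN2C(C)=O)ccc1OCc1cn(Cc2ccc([N+](=O)[O-])cc2)nn1` gives 1%
- compound 2 `COc1cc(C2CC(c3cc(OC)c(OC)c(OC)c3)=NN2C(C)=O)ccc1OCc1cn(Cc2ccc([N+](=O)[O-])cc2)nn1` gives 29%
- compound 3 `COc1ccc(C2=NN(C(C)=O)C(c3ccc(OCc4cn(Cc5ccc([N+](=O)[O-])cc5)nn4)c(OC)c3)C2)cc1` gives 8%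

Compound 1 stands lowest of the three. Its nearest neighbour is compound 3, reached by a number 7 percentage points higher from compound 1 to compound 3 (within the scatter), a difference that stays within the scatter of repeat measurements. Among the measured compounds shown here, the only step that moves clearly is a number 28 percentage points higher from compound 1 to compound 2 (beyond the scatter), where the 3,4,5-trimethoxyphenyl replaces the 4-bromophenyl, and in turn a number 21 percentage points lower from compound 2 to compound 3 (beyond the scatter) brings the number back down.

Compound 4 `COc1cc(C2CC(c3ccc(Cl)cc3)=NN2C(C)=O)ccc1OCc1cn(Cc2ccc([N+](=O)[O-])cc2)nn1` differs from compound 1 in one place: chloro in place of bromo on an aromatic carbon, sitting para to a large group on a six-membered aromatic ring of carbon only. The closest comparison is the exchange of the same bromo for a methoxy, a number 7 percentage points higher from compound 1 to compound 3 (within the scatter), which did not leave the scatter. A halogen swapped for a halogen at the same place gives no reason to expect more. The step from compound 1 to compound 4 is therefore estimated as a number 3 percentage points higher from compound 1 to compound 4 (within the scatter), within the scatter. Compound 4 is expected to give about 4%, with a range from -8% to 16%.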

Compound 4, percent growth inhibition at one concentration: 17%
For compound 4 the middle estimate is 13 percentage points below the measured one; measured number above the stated range.
By their numbers in this assay, from the lowest: compounds 1, 3 and 4 (each within the scatter of the next, the first and the last beyond it); then compound 2.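

At this place on the ring, para to a large group, one halogen does not simply stand in for another: chloro in place of bromo gives a number 16 percentage points higher from compound 1 to compound 4 (beyond the scatter) in this assay, so the identity of the halogen counts here even though the exchange of bromo for methoxy stayed within the scatter. Chloro in place of methoxy gives a number 9 percentage points higher from compound 3 to compound 4 (within the scatter) and so cannot be told apart from it, while the 4-chlorophenyl in place of the 3,4,5-trimethoxyphenyl still gives a number 12 percentage points lower from compound 2 to compound 4 (beyond the scatter) and leaves the trimethoxy pattern clearly ahead. No data here explain why the two halogens part.

The compounds shown leave open how a fluoro, an amine or a carboxylic acid would read at this same place. They also leave open whether a chloro added to the 3,4,5-trimethoxyphenyl pattern would change its reading.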